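This account rests on a few compounds, and the source may have more. Where it says the series, first, only, none or still open, it means among the compounds named here.

Measured so far in a functional assay on DU-145 cells (Homo sapiens) for cytotoxicity, read by CCK-8 assay, with a stated time of 4 days; on this read-out lower numbers stand for stronger inhibition and higher numbers for weaker inhibition:
compound 1 `Oc1ccc(-c2cc(-c3ccc(O)cc3)nc(-c3ccc(O)cc3)c2)cc1` gives 3160 nM;
compound 2 `Oc1ccccc1-c1cc(-c2ccccc2O)nc(-c2ccccc2O)c1` gives 5040 nM;
compound 3 `Oc1ccc(-c2cc(-c3ccccc3O)cc(-c3ccc(O)cc3)n2)cc1` gives 980 nM.

Compound 1 and compound 3 differ in one place: 4-hydroxyphenyl in place of 2-hydroxyphenyl on an aromatic carbon. On this change the assay recorded a 3.2-fold higher number from compound 3 to compound 1 (0.51 log units; beyond the scatter). Compound 2 and compound 3 are built from the same atoms, but the difference between the two cores is not broken down here; their two values show compound 3 with the lower number, beyond the scatter. The values of compound 1 and compound 2 lie within the scatter of each other.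

Compound 4 `Oc1ccc(-c2cc(-c3ccccc3O)nc(-c3ccccc3O)c2)cc1` has not yet been measured in this assay. It differs from compound 2 by 4-hydroxyphenyl in place of 2-hydroxyphenyl on an aromatic carbon. For the measured compounds named here, this is the same kind of change as the one from compound 3 to compound 1, not the same: in compound 2 the place is meta to two 2-hydroxyphenyl groups, whereas in compound 3 it is meta to two 4-hydroxyphenyl groups. A step of a 1.8-fold higher number from compound 2 to compound 4 (0.25 log units; within the scatter) is expected, resting on the single earlier case, because a 3.2-fold higher number from compound 3 to compound 1 (0.51 log units; beyond the scatter) points the same way. Compound 4 is accordingly estimated at 9000 nM, expected between 2500 nM and 30000 nM.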

Compound 4, half-maximal inhibitory concentration: > 50000 nM
Compound 4 gave a limit, no number (the forecaster's own chance of this, stated with the estimate: 15%); middle value at least 5.5-fold (0.74 log units) away from the limit.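

In this assay compound 4 gives > 50000 nM, which is a limit of the assay and not a number. The step reads an at least 9.9-fold higher number from compound 2 to compound 4 (0.99 log units; beyond the scatter), so 4-hydroxyphenyl in place of 2-hydroxyphenyl points the same way on both cores but does not carry over in size: the same change on two cores in this assay, a 3.2-fold higher number (0.51 log units; beyond the scatter) from compound 3 to compound 1 and an at least 9.9-fold higher number (0.99 log units; beyond the scatter) from compound 2 to compound 4, at least 3.0-fold (0.48 log units) apart, beyond the scatter of two such steps This shows that the size of the change depends on the core it is made on, but the larger step has only a lower bound, two cores give no rule for a third, and the data do not say what sets the two steps apart.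

The compounds shown carry only 2-hydroxyphenyl and 4-hydroxyphenyl groups, so it remains open how the series would read in this assay with a methoxy group or an amine in place of the hydroxyl. Also open, on these data alone, is whether the same change would give a step of either size on a core bearing such groups.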